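The source may hold more compounds than are shown below. What is called first, only, known or untested is meant among the compounds shown, and "the series" means these compounds.

Series notes. Compound 2 `CCN(CC)CCCOc1ccc(C(=O)/C=C/c2ccc(N(C)C)cc2)c(O)c1` is measured in an assay on isolated protein for inhibition of Amine oxidase [flavin-containing] A (Homo sapiens) (a lower number here means a stronger inhibitor, a higher number a weaker inhibitor), at 47100 nM, the highest of the two numbers in hand. Compound 1 `CCN(CCCCOc1ccc(/C=C/C(=O)c2ccc(N(C)C)cc2O)cc1)Cc1ccccc1N(C)C` gives 12300 nM in this assay; the two compounds differ in more than one place, so the gap between them cannot be tied to a single change. Compound 3 `CCN(CCCOc1ccc(C(=O)/C=C/c2ccc(N(C)C)cc2)c(O)c1)Cc1ccccc1` is not yet measured in this assay. Its difference from compound 2: phenyl in place of methyl on a saturated chain carbon bound to an amine nitrogen. For the measured compounds named here, no single-change step between measured compounds is available, so the size of this step rests on little. Going by the values given here, compound 1, the one measured compound carrying a benzyl group on the amine nitrogen, gives the lower number, 12300 nM. On that thin basis a modest move toward stronger inhibition is expected, a 2.4-fold lower number from compound 2 to compound 3 (0.37 log units; beyond the scatter). For compound 3 the expected value in this assay is 20000 nM, with a range of 7000 nM to 55000 nM.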

Compound 3, half-maximal inhibitory concentration: 82600 nM
Estimate against measurement, compound 3: 4.1-fold (0.62 log units) below; the measured number lies above the stated range.
By their numbers in this assay, from the lowest: compound 1; then compounds 2 and 3 (each within the scatter of the next).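

In this assay, for the compounds shown here, phenyl in place of methyl on a saturated chain carbon bound to an amine nitrogen gives a 1.8-fold higher number from compound 2 to compound 3 (0.24 log units; within the scatter), the first single-change step, and it leaves diethylamino and benzyl(ethyl)amino not separated by this read-out. The lower number of compound 1 therefore cannot be credited to a benzyl group on the amine nitrogen, as compound 1 differs from compound 2 and from compound 3 in more than one place. Nothing measured here offers an explanation for this result.

On these data alone, whether a different amine, such as morpholine or piperidine, or a longer chain such as phenethyl on that nitrogen would give a step beyond the scatter remains open. As far as these compounds go, the separate contributions of the dimethylamino group on the benzyl of compound 1 and of the chain linking the amine to the core also remain open.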